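Notes on compound 4: methyl in place of chloro

This account rests on a few compounds, and the source may have more. Where it says the series, first, only, none or still open, it means among the compounds named here.

Compound 3 `Clc1cc(N2C[C@H]3CCNC[C@H]32)cnc1Cl` gives the lowest number of the three measured in a functional assay on HEK293 cells for agonist activity at Neuronal acetylcholine receptor; alpha3/beta4 (Homo sapiens), read by FLIPR (on this read-out lower numbers stand for an effect already at smaller amounts and higher numbers for an effect only at larger amounts of compound), with 339 nM; compound 1 `COc1ccc(N2CC[C@@H]3CN[C@@H]3C2)cn1` gives 2400 nM and compound 2 `Clc1cc(N2C[C@@H]3CCNC[C@@H]32)cnc1Cl` gives 4110 nM. For the measured compounds named here, the only measured step, a 12-fold lower number from compound 2 to compound 3 (1.08 log units; beyond the scatter), is a change of configuration alone, and its size rests on (the fact that compounds 2 and 3 differ only in the configuration as drawn). Going by the values given here, compound 4 `Cc1cc(N2C[C@H]3CCNC[C@H]32)cnc1Cl` differs from compound 3 by methyl in place of chloro on an aromatic carbon, a change at an aromatic carbon that no measured step touches, so nothing measured bears on it and no direction can be drawn from the numbers. In this assay compound 4 is therefore expected close to compound 3, with a step of a 1.3-fold higher number from compound 3 to compound 4 (0.12 log units; within the scatter) that should stay within the usual scatter. The estimate for compound 4 is 450 nM, with a range from 130 nM to 1600 nM.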

Compound 4, half-maximal effective concentration: 298 nM
Estimate against measurement, compound 4: 1.5-fold (0.18 log units) above; the range from low to high includes it.
By their numbers in this assay, from the lowest: compounds 4 and 3 (each within the scatter of the next); then compounds 1 and 2 (each within the scatter of the next).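

In this assay, methyl in place of chloro on an aromatic carbon, ortho to a chloro group, gives a 1.1-fold lower number from compound 3 to compound 4 (0.06 log units; within the scatter), so at this position the two groups cannot be told apart. For the compounds shown here, this is the first measured step at an aromatic carbon, as the earlier step changed configuration alone. Nothing at hand bears on why the two groups read alike.

On these data alone, whether an amine, a carboxylic acid or a longer chain at this position would hold the number stays open. So does whether the mirror image of compound 4 would show a step like a 12-fold lower number from compound 2 to compound 3 (1.08 log units; beyond the scatter).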